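Chloro for fluoro on the aryl urea, measured in rice

The source may report more compounds than this note shows. Statements on the series, on what has been measured and on what is new or still open speak of the compounds shown alone.

Three compounds have been measured in an ADME assay on the whole organism with Oryza sativa as the target, tested at 10 uM; on this read-out higher numbers stand for a weaker effect at the one concentration tested and lower numbers for a stronger effect:
compound 1, `C[C@H](NC(=O)Nc1ccccc1F)c1ccccc1`, 65%
compound 2, `C[C@@H](NC(=O)Nc1cccc(F)c1)c1ccccc1`, 84%
compound 3, `C[C@H](NC(=O)Nc1ccccc1Cl)c1ccccc1`, 106%

Compound 1 and compound 3 share one core and differ only in chloro in place of fluoro on an aromatic carbon; that change made the step of a number 41 percentage points higher from compound 1 to compound 3 (beyond the scatter). Compound 2 has the same atoms as compound 1, joined differently; the difference between the two cores is not broken down here. In this assay compound 2 gives 84%, which stands beyond the scatter from compound 1 on one side and from compound 3 on the other, a number above compound 1 and below compound 3.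

Compound 4, `C[C@@H](NC(=O)Nc1cccc(Cl)c1)c1ccccc1`, has not yet been measured. It differs from compound 2 by chloro in place of fluoro on an aromatic carbon. Within the data shown here, this is the same kind of change as the one from compound 1 to compound 3, but not the same: there the chloro entered ortho to a large group, here it enters meta to a large group.

Among the measured compounds shown here, since the one measured instance of this change is a number 41 percentage points higher from compound 1 to compound 3 (beyond the scatter), compound 4 is expected to move in the same direction from compound 2, though the change sits at a different place, so a step of a number 21 percentage points higher from compound 2 to compound 4 (beyond the scatter) is estimated. For compound 4 in this assay a value of 105% is expected, most likely between 85% and 125%.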

Compound 4, a percentage reported as activity, at one concentration (the size of the read-out at that concentration, not a potency): 83%
Beside the measured number, compound 4's estimate is 22 percentage points above it; the measured number lies below the stated range.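

In this assay, chloro in place of fluoro on an aromatic carbon, meta to a large group, gave a number 1 percentage points lower from compound 2 to compound 4 (within the scatter), so compound 4 does not separate from compound 2 on this read-out. The same change therefore did not carry over at a similar size between the two cores of this series: the same change on two cores in this assay, a number 41 percentage points higher (beyond the scatter) from compound 1 to compound 3 and a number 1 percentage points lower (within the scatter) from compound 2 to compound 4, 42 percentage points apart, beyond the scatter of two such steps This shows that the step measured on one core cannot simply be transferred to the other, but with only two instances it does not show which difference between the cores sets the steps apart, nor how the change would behave on any further core.

From the compounds shown here alone, whether a bromo, a methyl or a methoxy group on the same aromatic carbon would follow the large step seen on the core of compound 1 or the flat one seen on the core of compound 2 remains open. Also open, going by these compounds, is what a trifluoromethyl group, a nitrile or an amine at that place would do on either core.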